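This account rests on a few compounds, and the source may have more. Where it says the series, first, only, none or still open, it means among the compounds named here.

Compound 1 `COc1ccc(/C=C2\CCC/C(=C\c3cccc(OC)c3OC)C2=O)cc1` was examined in a functional assay on A549 cells (Homo sapiens) for cytotoxicity, read by MTT assay, with a stated time of 72 h; a higher number here means a weaker inhibitor, a lower number a stronger inhibitor. In this assay compound 1 gives > 20000 nM, which is a limit of the assay and not a number. Compound 2 `COc1cccc(/C=C2\CCC/C(=C\c3cccc(O)c3)C2=O)c1OC` carries 3-hydroxyphenyl in place of 4-methoxyphenyl on a double-bonded chain carbon bound to a double-bonded ring carbon. In this assay compound 2 gives > 20000 nM, again a limit. The size of this change is a step that the two limits leave unreadable from compound 1 to compound 2, and it stays unreadable because the limit of > 20000 nM in this assay, at which 3 of the 3 values shown sit, covers both ends of the step.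

Compound 3 `COc1ccc(/C=C2\CCC/C(=C\c3ccc(OC)c(OC)c3)C2=O)cc1` is built from the same atoms as compound 1, joined differently; the difference between the two cores is not broken down here. In this assay compound 3 gives > 20000 nM, once more a limit.

Compound 4 `COc1ccc(/C=C2\CCC/C(=C\c3cccc(O)c3)C2=O)cc1OC` has not been measured. It differs from compound 3 by 3-hydroxyphenyl in place of 4-methoxyphenyl on a double-bonded chain carbon bound to a double-bonded ring carbon, the same change that separates compound 1 from compound 2. Beside that unreadable earlier step, the step here is expected to be a step that the limit leaves unreadable from compound 3 to compound 4. This expectation rests on compound 3, whose value > 20000 nM is a limit, and on the same change leaving compound 2 at a limit as well. Compound 4 is therefore estimated at 30000 nM, within 12000 nM to 100000 nM, and is expected to be reported as a limit.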

Compound 4, half-maximal inhibitory concentration: 4300 nM
Estimate against measurement, compound 4: 7.0-fold (0.84 log units) above, and the stated range ends above it.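

On the core of compound 3, 3-hydroxyphenyl in place of 4-methoxyphenyl gives an at least 4.6-fold lower number from compound 3 to compound 4 (0.66 log units; beyond the scatter) in this assay, and because compound 3 has no exact value, this size is only a lower bound. With the same change on the core of compound 1, compound 2 gives > 20000 nM, a limit of the assay and not a number. The change thus brings a measured value on one core but not on the other, which shows that a readable gain does not carry to every core in this series, yet it does not show how the two steps compare, because the step on the core of compound 1 cannot be read: the limit of > 20000 nM in this assay, at which 3 of the 4 values shown sit.

The compounds shown leave open whether the same change would give a measured value on any further core. They also leave open what another group in the same place, such as 3-aminophenyl, with an amine in place of the hydroxyl, or a carboxylic acid, would give in this assay.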